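This account rests on a few compounds, and the source may have more. Where it says the series, first, only, none or still open, it means among the compounds named here.

In a functional assay on PC-3 cells (Homo sapiens) for inhibition, with a stated time of 48 h, tested at 50 uM (on this read-out higher numbers stand for more inhibition of growth at the one concentration tested and lower numbers for less inhibition of growth), compound 1 `C=C[C@@](C)(/C=C/c1ccc(OC(C)=O)cc1)CCC=C(C)C` gives 67%, while compound 2 `C=C[C@@](C)(/C=C/c1ccc(OC(=O)CCCCC)cc1)CCC=C(C)C` gives 28%, the lower of the two numbers. Compound 3 `C=C[C@@](C)(/C=C/c1ccc(OC)cc1)CCC=C(C)C` departs from compound 2 through (methyl in place of pentylcarbonyl on an oxygen on an aromatic ring). Within the data shown here, only one measured step bears on this change: a number 39 percentage points lower from compound 1 to compound 2 (beyond the scatter), a large step that lengthens the chain on the carbonyl. Compound 3 has no carbonyl on that oxygen, so this step is only an indirect guide. Removing the pentylcarbonyl is nevertheless expected to reverse much of that loss, giving an estimated a number 27 percentage points higher from compound 2 to compound 3 (beyond the scatter). For compound 3, the estimated value is 55%, with an expected range from 35% to 75%.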

Compound 3, percent growth inhibition at one concentration: 44%
For compound 3 the middle estimate is 11 percentage points above the measured one, within the range that was stated.
By their numbers in this assay, from the lowest: compound 2; then compound 3; then compound 1.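

In this assay the oxygen on the aromatic ring still carries growth inhibition without any carbonyl on it. Methyl in place of pentylcarbonyl gives a number 16 percentage points higher from compound 2 to compound 3 (beyond the scatter), yet methyl in place of acetyl gives a number 23 percentage points lower from compound 1 to compound 3 (beyond the scatter), so the direction of the change depends on which ester is replaced. Nothing available explains this order.

From the compounds shown here alone, what a free hydroxyl on this oxygen would give remains open. So does the reading for an ester chain of a length other than acetyl or pentylcarbonyl, such as butanoyl.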